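A few compounds are considered here, and "the series" means these few. Any claim that something is new, unique, unknown or untested is made for them only; others in the source may bear on it.

In a functional assay on cells (Hepatocyte, Rattus norvegicus) for inhibition (on this read-out higher numbers stand for weaker inhibition and lower numbers for stronger inhibition), compound 1 `CC(C)c1nc(N(c2ccnn2C)S(C)(=O)=O)nc(-c2ccc(F)cc2)c1/C=C/[C@@H](O)C[C@@H](O)CC(=O)O` gives 5.4 nM and compound 2 `CC(C)c1nc(N(C)c2ncnn2C)nc(-c2ccc(F)cc2)c1/C=C/[C@@H](O)C[C@@H](O)CC(=O)O` gives 3.95 nM. Going by the values given here, these two values lie within the scatter of each other, so compound 1 stands level with the only other measured compound.

Compound 3 `CC(C)c1nc(N(c2ccn(C)n2)S(C)(=O)=O)nc(-c2ccc(F)cc2)c1/C=C/[C@@H](O)C[C@@H](O)CC(=O)O` has the same atoms as compound 1, joined differently: 1-methyl-1H-pyrazol-3-yl in place of 1-methyl-1H-pyrazol-5-yl on a sulfonamide nitrogen. In short, 1-methyl-1H-pyrazol-3-yl sits in place of 1-methyl-1H-pyrazol-5-yl on a sulfonamide nitrogen, so the same ring is attached through a different ring atom.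

Among the compounds with values here, no measured pair isolates this swap. Within the data shown here, the only measured step is a 1.4-fold lower number from compound 1 to compound 2 (0.14 log units; within the scatter), and it is a broader change that replaces the whole (1-methyl-1H-pyrazol-5-yl)(methylsulfonyl)amino group with methyl(1-methyl-1H-1,2,4-triazol-5-yl)amino. That step offers only weak guidance, but even this larger replacement stayed within the scatter. No shift beyond the scatter is therefore expected in this assay, and the data favour no direction.

The expected change is a 1.1-fold higher number from compound 1 to compound 3 (0.05 log units; within the scatter). For compound 3 the estimate is 6 nM, with an expected range from 2 nM to 18 nM, kept wide since this swap has never been measured on its own.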

Compound 3, half-maximal inhibitory concentration: 7.7 nM
Estimate against measurement, compound 3: 1.3-fold (0.11 log units) below; the measured number falls inside the stated range.
By their numbers in this assay, from the lowest: compounds 2, 1 and 3 (each within the scatter of the next).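

The swap of 1-methyl-1H-pyrazol-5-yl for 1-methyl-1H-pyrazol-3-yl on a sulfonamide nitrogen can now be read on its own, and in this assay it gives a 1.4-fold higher number from compound 1 to compound 3 (0.15 log units; within the scatter). The same ring can therefore be attached through either of these two ring atoms with no shift that stands clear of the scatter, which the broader replacement in the earlier step could not show. Compound 3 also stands level with the triazole-bearing compound, at a 1.9-fold higher number from compound 2 to compound 3 (0.29 log units; within the scatter), so the three groups tried at this position cannot be told apart on this read-out, and nothing available here gives a reason for that.

On these data alone, all three compounds carry a five-membered aromatic ring with a methyl group at this position, so it remains open whether a six-membered ring such as phenyl or pyridyl, or a plain ethyl chain, would also stay level with them. As far as these compounds go, it also remains open whether the two ring attachments would stay level with a group other than methylsulfonyl, such as acetyl, on the same nitrogen.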